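Cathepsin S series: phenyl removal on the side chain

The source may report more compounds than this note shows. Statements on the series, on what has been measured and on what is new or still open speak of the compounds shown alone.

Measured compounds:
- compound 1, `C[C@@H](CNc1ccc(OC(F)(F)F)cc1)NC(=O)[C@H](CCC1CCCCC1)CC(=O)N1CCOCC1`: 95 nM
- compound 2, `O=C(N[C@@H](CCc1ccccc1)CNc1ccc(OC(F)(F)F)cc1)[C@@H](CC(=O)N1CCOCC1)CC1CCCCC1`: 18 nM
- compound 3, `CC(C)[C@@H](CNc1ccc(OC(F)(F)F)cc1)NC(=O)[C@@H](CC(=O)N1CCOCC1)CC1CCCC1`: 38 nM

In an assay on isolated protein for inhibition of cathepsin S (Homo sapiens) (on this read-out lower numbers stand for stronger inhibition and higher numbers for weaker inhibition), compound 2 gives the lowest of the three numbers; compound 3 stands nearest, beyond the scatter, and compound 1 stands furthest. Compound 1 and compound 3 differ from compound 2 in more than one place, so their numbers show only where they lie, not a single step.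

Compound 4, `CC[C@@H](CNc1ccc(OC(F)(F)F)cc1)NC(=O)[C@@H](CC(=O)N1CCOCC1)CC1CCCCC1`, has not yet been measured in this assay. Its change from compound 2 is hydrogen in place of phenyl on a saturated chain carbon, three bonds along the chain from an amide-type nitrogen, which cut one bond further out reads phenethyl to ethyl. Among the measured compounds shown here, no measured pair shows this change on its own. The shortest side chains among the measured compounds belong to compound 1 and compound 3, and both give higher numbers than compound 2, but each also carries a different group elsewhere, so only the direction can be read from them.

The expected step of a 3.1-fold higher number from compound 2 to compound 4 (0.49 log units; beyond the scatter) is therefore a moderate move to a higher number, beyond the scatter. The estimate for compound 4 in this assay is 55 nM, with a range from 22 nM to 140 nM.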

Compound 4, inhibition constant: 16 nM
For compound 4 the middle estimate is 3.4-fold (0.54 log units) above the measured one, outside the stated range (below it).
By their numbers in this assay, from the lowest: compounds 4 and 2 (each within the scatter of the next); then compound 3; then compound 1.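

Working notes on the side chain: in this assay, hydrogen in place of phenyl on a saturated chain carbon, three bonds along the chain from an amide-type nitrogen, gives a 1.1-fold lower number from compound 2 to compound 4 (0.05 log units; within the scatter). Among the compounds shown here, this is the first reading of this change on its own, and it shows that, in this pair, the phenyl ring at the end of the phenethyl chain is not needed for a number at this level: the ethyl chain of compound 4 serves as well in this assay. Nothing available explains why the phenyl ring can go without a visible change in the number.

Still open, on these data alone, is how this position responds to other groups, such as a propyl chain, a longer alkyl chain, or a chain ending in an amine or a carboxylic acid, since only phenethyl and ethyl can be compared directly here. Also open, as far as these compounds go, is whether the phenethyl to ethyl change reads the same way with other groups elsewhere on the shared core, as this reading rests on a single pair.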